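The source may report more compounds than this note shows. Statements on the series, on what has been measured and on what is new or still open speak of the compounds shown alone.

Two measured compounds share a core and differ only in the group carried on a saturated chain carbon bound to an aromatic nitrogen. Compound 1, `Cc1cc(C)c(Oc2cc(Nc3ccc(C#N)cc3)ncc2C(=O)NCc2cn(Cc3ccccc3[N+](=O)[O-])nn2)c(C)c1`, carries a 2-nitrophenyl there; compound 2, `Cc1cc(C)c(Oc2cc(Nc3ccc(C#N)cc3)ncc2C(=O)NCc2cn(Cc3cccc(Cl)c3)nn2)c(C)c1`, carries a 3-chlorophenyl. In an ADME assay on MT4 cells (Homo sapiens) for cytotoxicity, read by MTT assay, with a stated time of 5 days (a lower number here means that less compound is tolerated, a higher number that more compound is tolerated), compound 1 gives only a limit, > 212000 nM. In this assay compound 2 gives 187000 nM, the only number shown for the pair, so compound 2 stands as the one compound with a proper value here. The step between them, an at least 1.1-fold lower number from compound 1 to compound 2 (0.05 log units; that floor lies within the scatter), is too small to call a real change, since one end is the limit of > 212000 nM in this assay, at which 1 of the 2 values shown sits.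

Compound 3, `Cc1cc(C)c(Oc2cc(Nc3ccc(C#N)cc3)ncc2C(=O)NCc2cn(Cc3ccccc3C)nn2)c(C)c1`, is the next compound to be measured in this assay. It differs from compound 2 in a single place: 2-methylphenyl in place of 3-chlorophenyl on a saturated chain carbon bound to an aromatic nitrogen. Going by the values given here, the one measured step bears on it only loosely, as it swaps a different group at the same place and stays within the scatter. For compound 3 the expectation is therefore a number of similar size, with a step from compound 2 estimated as a 1.0-fold higher number from compound 2 to compound 3 (0.01 log units; within the scatter). The value of compound 3 in this assay is expected to come out near 190000 nM, with a likely range of 95000 nM to 260000 nM.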

Compound 3, half-maximal cytotoxic concentration: >= 164000 nM
Compound 3 was reported as a limit (the forecaster's own chance of this, stated with the estimate: 45%); the middle value does not contradict the limit.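

In this assay compound 3 gives only a limit (>= 164000 nM), so its steps from compound 1 and from compound 2 cannot be read. The compounds shown leave open whether 2-methylphenyl, 3-chlorophenyl and 2-nitrophenyl at this place truly differ in how much compound the cells tolerate, as only compound 2 has a proper number.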